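Methyl on the fused ring of compound 1

The compounds below may be only part of what the source reports. "The series", "measured", "known", "first", "only" and "open" are said of these compounds alone.

Working notes on the series. Compound 1 `O=c1[nH]c2ccccc2cc1/C=N/Cc1ccccc1` is the reference point; in a functional assay, read by spectrophotometry, with a stated time of 1 h (a lower number here means a stronger inhibitor, a higher number a weaker inhibitor), compound 1 gives 3140000 nM. Compound 2 `CCCC/N=C/c1cc2ccccc2[nH]c1=O` gives 7680000 nM in this assay, and compound 3 `NS(=O)(=O)CC(=O)N/N=C/c1cc2ccccc2[nH]c1=O` gives 8730000 nM. Compound 1 therefore stands lowest of the three numbers, and both of the other compounds lie beyond the scatter above it. Among the compounds with values here, the one step that can be followed is a 2.4-fold higher number from compound 1 to compound 2 (0.39 log units; beyond the scatter). Between compound 1 and compound 3 only the two values are known, and compound 3 shows the higher number.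

Compound 4 `Cc1ccc2[nH]c(=O)c(/C=N/Cc3ccccc3)cc2c1` is the next compound for this assay. Against compound 1 the change is methyl in place of hydrogen on an aromatic carbon. Within the data shown here, no measured step touches the core of compound 1 at this place: the step from compound 1 to compound 2 alters the group on the saturated chain carbon bound to the double-bonded nitrogen, and the pair of compound 1 and compound 3 differs at the same side of the molecule. Among the measured compounds shown here, with no measured step bearing on this change, a step of a 1.0-fold lower number from compound 1 to compound 4 (0.02 log units; within the scatter) is expected for compound 4, which is no change beyond the scatter. Compound 4 is thus estimated at 3000000 nM in this assay, with a range from 1200000 nM to 7500000 nM.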

Compound 4, half-maximal inhibitory concentration: 6920000 nM
The estimate for compound 4 lay 2.3-fold (0.36 log units) below the measured number; the range from low to high includes it.
By their numbers in this assay, from the lowest: compound 1; then compounds 4, 2 and 3 (each within the scatter of the next).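

The aromatic carbon of the shared core, meta to a fused ring and para to a fused ring, now has a measured step of its own: in this assay methyl in place of hydrogen gives a 2.2-fold higher number from compound 1 to compound 4 (0.34 log units; beyond the scatter) and so makes a weaker inhibitor. Within the data shown here, until now, the only measured step altered the group on the saturated chain carbon, so this is the first sign that the number also responds to a change on the aromatic carbon, and the response is modest. Nothing available bears on why the methyl raises the number.

As far as these compounds go, whether an ethyl, a methoxy, a chlorine or an amine at this carbon would move the number in the same direction stays open. From the compounds shown here alone, it is also open whether the methyl step would hold with the side chain of compound 2 or compound 3.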